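Returning to a small alkyl on the sulfur

The compounds below may be only part of what the source reports. "The series", "measured", "known", "first", "only" and "open" are said of these compounds alone.

The series shares one core, varied only at the group carried on the sulfur. Compound 1 `CC(C)CSc1n[nH]c(-n2[se]c3ccccc3c2=O)n1` bears isobutyl there; in a functional assay on A549 cells (Homo sapiens) for antiproliferative activity, read by CCK-8 assay, with a stated time of 48 h (on this read-out lower numbers stand for stronger inhibition and higher numbers for weaker inhibition), compound 1 gives 37800 nM. Compound 3 `O=c1c2ccccc2[se]n1-c1nc(SCc2ccc(F)cc2)n[nH]1` carries a 4-fluorobenzyl group, and in this assay compound 3 gives 36400 nM. Compound 2 `Cc1ccc(CSc2n[nH]c(-n3[se]c4ccccc4c3=O)n2)cc1` carries a 4-methylbenzyl group. In this assay compound 2 reaches only a limit, > 50000 nM, so no number is known for it; this is the limit of > 50000 nM in this assay, at which 1 of the 3 values shown sits. The measured steps are all small: an at least 1.3-fold higher number from compound 1 to compound 2 (0.12 log units; that floor lies within the scatter), a 1.0-fold lower number from compound 1 to compound 3 (0.02 log units; within the scatter), and an at least 1.3-fold lower number from compound 2 to compound 3 (0.13 log units; that floor lies within the scatter).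

Compound 4 `CC(C)Sc1n[nH]c(-n2[se]c3ccccc3c2=O)n1` differs from compound 2 by isopropyl in place of 4-methylbenzyl on a sulfur. The step from compound 1 to compound 2 is the one that bears on it, since it exchanged a small alkyl for a benzyl group, and it produced at most a modest rise. Reversing that kind of exchange, with isopropyl rather than isobutyl, is therefore expected to bring the number back into the neighbourhood of compound 1, an expected at least 1.2-fold lower number from compound 2 to compound 4 (0.09 log units; that floor lies within the scatter), although a limit for compound 2 makes the size uncertain. Compound 4 is accordingly expected to give about 40000 nM in this assay, within a range from 15000 nM to 100000 nM.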

Compound 4, half-maximal inhibitory concentration: 36600 nM
Beside the measured number, compound 4's estimate is 1.1-fold (0.04 log units) above it; the measured number falls inside the stated range.
By their numbers in this assay, from the lowest: compounds 3, 4 and 1 (each within the scatter of the next). At a limit, above all of these: compound 2.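

Isopropyl in place of isobutyl gives a 1.0-fold lower number from compound 1 to compound 4 (0.01 log units; within the scatter), and isopropyl in place of 4-fluorobenzyl gives a 1.0-fold higher number from compound 3 to compound 4 (0.00 log units; within the scatter), so in this assay the read-out does not tell these small alkyl groups from a benzyl group that carries a ring. Within the data shown here, the exchange for 4-methylbenzyl reads an at least 1.3-fold lower number from compound 2 to compound 4 (0.13 log units; that floor lies within the scatter), and its true size stays open because compound 2 carries only a limit: the limit of > 50000 nM in this assay, at which 1 of the 4 values shown sits. Compounds 1, 3 and 4 thus lie within the scatter of one another, which holds for these three groups on the sulfur, while compound 2 is the one compound that cannot be placed among them.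

On these data alone, what an amine or a carboxylic acid at the end of a longer chain on the sulfur would do to the number remains open. Also open, as far as these compounds go, are the actual value of compound 2 and whether a change to the shared core, rather than to the group on the sulfur, would move the number beyond the scatter.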